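Cytotoxicity notes: changing the group on the amide-type nitrogen

The source may hold more compounds than are shown below. What is called first, only, known or untested is meant among the compounds shown, and "the series" means these compounds.

Measured in a functional assay on MT4 cells (Homo sapiens) for cytotoxicity, read by MTT assay; on this read-out higher numbers stand for lower toxicity in this test and lower numbers for higher toxicity in this test:
- compound 1 `Cc1cc(C)cc(S(=O)(=O)c2c(C(=O)NCC(=O)NN)[nH]c3ccc(Cl)cc23)c1`: > 100 uM (a limit)
- compound 2 `O=C(NN1CCOC1=O)c1[nH]c2ccc(Cl)cc2c1S(=O)(=O)c1ccccc1`: > 100 uM (a limit)
- compound 3 `Cc1cc(C)cc(S(=O)(=O)c2c(C(=O)NN3CCOC3=O)[nH]c3ccc(Cl)cc23)c1`: 100 uM

Compound 3 alone carries a number rather than a limit. The other two stop at the limit of > 100 uM in this assay, at which 2 of the 3 values shown sit. The next structure, compound 4 `Cc1cc(C)cc(S(=O)(=O)c2c(C(=O)NNC(C)C)[nH]c3ccc(Cl)cc23)c1`, has isopropylamino in place of 2-oxo-1,3-oxazolidin-3-yl on an amide-type nitrogen. The nearest measured change, at this same place, is a number no higher from compound 1 to compound 3 (the limit leaves the size open). The change on a sulfonyl sulfur, a number no higher from compound 2 to compound 3 (the limit leaves the size open), bears on it less directly. Neither size can be read, so no direction can be argued from them. The expected outcome is a 1.3-fold lower number from compound 3 to compound 4 (0.10 log units; within the scatter), with nothing beyond the scatter anticipated. For compound 4 the estimated value is 80 uM, with an expected range of 20 uM to 200 uM.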

Compound 4, half-maximal toxic concentration: > 100 uM
Compound 4: only a limit was reported; the forecaster's own chance of this, stated with the estimate: 40%; at least 1.2-fold (0.09 log units) between middle value and limit.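

In this assay, isopropylamino in place of 2-oxo-1,3-oxazolidin-3-yl on the amide-type nitrogen gives a number no lower from compound 3 to compound 4 (the limit leaves the size open). A group with no ring and with a hydrogen-bond donor can therefore sit on this nitrogen without lowering the number, whereas the step between compound 1 and compound 4 cannot be read, since both values are limits. Most of the series now sits at a single limit: the limit of > 100 uM in this assay, at which 3 of the 4 values shown sit.

Still open, as far as these compounds go, is whether a primary amine, a carboxylic acid or a longer alkyl chain on this nitrogen would give a number below that limit in this assay.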